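The source may hold more compounds than are shown below. What is called first, only, known or untested is meant among the compounds shown, and "the series" means these compounds.

Three close relatives built on one shared core have been measured in a functional assay for inhibition of sodium/hydrogen exchanger (Oryctolagus cuniculus); a higher number here means a weaker inhibitor, a lower number a stronger inhibitor. Compound 1 `Cc1cc(F)c(S(C)(=O)=O)cc1C(=O)N=C(N)N` gives 44 nM. Compound 2 `Cc1cc(C)c(S(C)(=O)=O)cc1C(=O)N=C(N)N` gives 11 nM. Compound 3 `Cc1cc(-c2ccccc2)c(S(C)(=O)=O)cc1C(=O)N=C(N)N` gives 19 nM. Among these three numbers compound 3 stands second highest: one neighbouring step is a 1.7-fold higher number from compound 2 to compound 3 (0.24 log units; within the scatter) and lies within the scatter, whereas the other step is a 2.3-fold lower number from compound 1 to compound 3 (0.36 log units; beyond the scatter), which is beyond the scatter.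

Going by the values given here, compound 4 `Cc1cc(Sc2ccncc2)c(S(C)(=O)=O)cc1C(=O)N=C(N)N` is the next step from compound 3. (pyridin-4-yl)sulfanyl in place of phenyl on an aromatic carbon No measured step swaps a phenyl for a (pyridin-4-yl)sulfanyl, so the change itself has no direct precedent. What is known concerns the same aromatic carbon: replacing fluoro by methyl gave a 4.0-fold lower number from compound 1 to compound 2 (0.60 log units; beyond the scatter), replacing fluoro by phenyl gave a 2.3-fold lower number from compound 1 to compound 3 (0.36 log units; beyond the scatter), and moving from methyl to phenyl gave a 1.7-fold higher number from compound 2 to compound 3 (0.24 log units; within the scatter), within the scatter. Two rather different groups at this place thus give numbers that cannot be told apart, while fluoro stands clearly higher. On this basis no step beyond the scatter is expected for compound 4 in this assay. The expected step is a 1.1-fold higher number from compound 3 to compound 4 (0.02 log units; within the scatter). Compound 4 is estimated at 20 nM, with a likely range from 8 nM to 50 nM.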

Compound 4, half-maximal inhibitory concentration: 13 nM
Estimate against measurement, compound 4: 1.5-fold (0.19 log units) above; the measured number falls inside the stated range.
By their numbers in this assay, from the lowest: compounds 2, 4 and 3 (each within the scatter of the next); then compound 1.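

In this assay, this aromatic carbon now accepts a third, quite different group, since (pyridin-4-yl)sulfanyl brings in a sulfur atom and a ring nitrogen, and counts hydrogen-bond acceptors where phenyl has none. Even so, the numbers do not separate: a 1.5-fold lower number from compound 3 to compound 4 (0.16 log units; within the scatter) and a 1.2-fold higher number from compound 2 to compound 4 (0.07 log units; within the scatter) are both steps that stay within the scatter, so methyl, phenyl and (pyridin-4-yl)sulfanyl cannot be told apart here, and only compound 1, with its fluoro group, goes against this picture, as a 3.4-fold lower number from compound 1 to compound 4 (0.53 log units; beyond the scatter) shows a step beyond the scatter. Nothing at hand bears on why these groups give such similar numbers.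

Because the sulfur atom and the ring nitrogen enter together, the compounds shown cannot say what either contributes alone, and a phenylsulfanyl group, which keeps the sulfur and drops the nitrogen, would begin to pull the two apart. From the compounds shown here alone, it also remains open whether this position tolerates groups of another kind, such as an amine, a carboxylic acid or a longer chain, as readily as it tolerates these three.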